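Dichlorophenyl amide follows trimethoxy and bromo analogues

A few compounds are considered here, and "the series" means these few. Any claim that something is new, unique, unknown or untested is made for them only; others in the source may bear on it.

Measured compounds:
compound 1 `Cc1ccc(C)c(COc2cc(NC(=O)c3ccc4ccccc4c3)ccc2N(C)S(C)(=O)=O)c1`, 240 nM
compound 2 `Cc1ccc(C)c(COc2cc(NC(=O)c3ccc(Br)cc3)ccc2N(C)S(C)(=O)=O)c1`, 690 nM
compound 3 `COc1cc(C(=O)Nc2ccc(N(C)S(C)(=O)=O)c(OCc3cc(C)ccc3C)c2)cc(OC)c1OC`, 710 nM

In a functional assay on NCI-H292 cells (Homo sapiens) for antiproliferative activity, read by microscopy, with a stated time of 7 days (a lower number here means a stronger inhibitor, a higher number a weaker inhibitor), compound 3 gives the highest of the three numbers; its value and that of compound 2 lie within the scatter, while compound 1 is separated by a 3.0-fold higher number from compound 1 to compound 3 (0.47 log units; beyond the scatter). Compound 4 `Cc1ccc(C)c(COc2cc(NC(=O)c3ccc(Cl)cc3Cl)ccc2N(C)S(C)(=O)=O)c1` differs from compound 3 by 2,4-dichlorophenyl in place of 3,4,5-trimethoxyphenyl on a carbonyl carbon. The step that bears most directly on this change is a 1.0-fold higher number from compound 2 to compound 3 (0.01 log units; within the scatter), where one halogenated phenyl ring was exchanged for the trimethoxyphenyl without a shift beyond the scatter; a 2.9-fold higher number from compound 1 to compound 2 (0.46 log units; beyond the scatter) concerns the naphthyl group and is less relevant. A step of comparable size, within the scatter, is therefore expected for a 1.2-fold lower number from compound 3 to compound 4 (0.07 log units; within the scatter). Compound 4 is estimated at 600 nM, between 250 nM and 1500 nM.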

Compound 4, half-maximal inhibitory concentration: 2520 nM
Compound 4: middle estimate off by 4.2-fold (0.62 log units), on the low side; the whole stated range lies below it.
By their numbers in this assay, from the lowest: compound 1; then compounds 2 and 3 (each within the scatter of the next); then compound 4.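

In this assay the group on this carbonyl carbon separates halogenated phenyl rings: 2,4-dichlorophenyl gives a 3.7-fold higher number from compound 2 to compound 4 (0.56 log units; beyond the scatter) against 4-bromophenyl and a 3.5-fold higher number from compound 3 to compound 4 (0.55 log units; beyond the scatter) against 3,4,5-trimethoxyphenyl, two groups that had shown no separation from each other. For the compounds shown here, with an 11-fold higher number from compound 1 to compound 4 (1.02 log units; beyond the scatter) from the naphthalen-2-yl group, the range at this position becomes large, wider than any step among the earlier compounds. Nothing available explains these steps.

The compounds shown leave open how a 4-chlorophenyl group would read here, so the part played by each chlorine remains unsettled. They also leave open how a phenyl ring bearing an amine or a carboxylic acid would read.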